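The source may hold more compounds than are shown below. What is called first, only, known or untested is meant among the compounds shown, and "the series" means these compounds.

In an ADME assay on HFF cells (Homo sapiens) for cytotoxicity, read by MTT assay, with a stated time of 72 h (on this read-out higher numbers stand for weaker inhibition and lower numbers for stronger inhibition), compound 3 `COc1ccc(-c2cn(C[C@H](O)[C@H]3OC(=O)C(OCc4ccccc4)=C3OCc3ccccc3)nn2)cc1` gives < 10 nM, which is a limit and not a number; it is the limit of < 10 nM in this assay, at which 1 of the 3 values shown sits. In the same assay, compound 1 `O=C1O[C@H]([C@@H](O)Cn2cc(-c3cccc(O)c3)nn2)C(OCc2ccccc2)=C1OCc1ccccc1` gives 39000 nM and compound 2 `O=C1O[C@H]([C@@H](O)Cn2cc(CCCCl)nn2)C(OCc2ccccc2)=C1OCc1ccccc1` gives 27100 nM. Compound 4 `O=C1O[C@H]([C@@H](O)Cn2ccnn2)C(OCc2ccccc2)=C1OCc1ccccc1` differs from compound 3 as follows: hydrogen in place of 4-methoxyphenyl on an aromatic carbon. The bearing steps are an at least 3900-fold lower number from compound 1 to compound 3 (3.59 log units; beyond the scatter) and an at least 2700-fold lower number from compound 2 to compound 3 (3.43 log units; beyond the scatter), both large, with 4-methoxyphenyl entering each time. By contrast, a 1.4-fold lower number from compound 1 to compound 2 (0.16 log units; within the scatter) shows no change beyond the scatter. Neither comparison has hydrogen as the other group, so the expectation is loose. A large step to a higher number is expected in this assay. The expected step is an at least 1500-fold higher number from compound 3 to compound 4 (3.17 log units; beyond the scatter). For compound 4 the estimated value is 15000 nM, with an expected range of 500 nM to 80000 nM.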

Compound 4, half-maximal inhibitory concentration: 610 nM
The estimate for compound 4 lay 25-fold (1.39 log units) above the measured number, and the stated range covers the measured number.
By their numbers in this assay, from the lowest: compound 4; then compounds 2 and 1 (each within the scatter of the next). At a limit, below all of these: compound 3.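

Hydrogen on this aromatic carbon gives a middle position in this assay, with the number rising on one side (an at least 61-fold higher number from compound 3 to compound 4 (1.78 log units; beyond the scatter)) and falling on the others (a 44-fold lower number from compound 2 to compound 4 (1.65 log units; beyond the scatter)) (a 64-fold lower number from compound 1 to compound 4 (1.81 log units; beyond the scatter)). A six-membered aromatic ring at this carbon therefore does not set the direction alone, since compound 1 and compound 3 both carry one and lie on opposite sides of compound 4. Compound 3 stands at a limit, so its step gives only a bound: the limit of < 10 nM in this assay, at which 1 of the 4 values shown sits.

Open, from the compounds shown here alone, is whether the methoxy group or its ring place separates compound 3 from compound 1. A plain phenyl, an amine or a carboxylic acid on this carbon could test how far the trend extends.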